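A few compounds are considered here, and "the series" means these few. Any claim that something is new, unique, unknown or untested is made for them only; others in the source may bear on it.

Measured in an ADME assay for permeability, using PAMPA, with a stated time of 4 h, at pH 5.5; a higher number here means that the compound crosses the layer faster, a lower number that the compound crosses the layer more slowly:
- compound 1 `NC/C=C/CN(C[C@H]1Cc2ncccc2CN1)[C@H]1CCCc2cccnc21`: 2 nm/s
- compound 2 `NC(=O)NCCCCN(C[C@H]1Cc2ncccc2CN1)[C@H]1CCCc2cccnc21`: 7 nm/s

Of these two compounds, compound 2 stands higher, at 7 nm/s. Compound 3 `CCN(CC)CCCCN(C[C@H]1Cc2ncccc2CN1)[C@H]1CCCc2cccnc21`, not yet measured in this assay, differs from compound 2 as follows: diethylamino in place of ureido on a saturated chain carbon, four bonds along the chain from an amine nitrogen. Thus diethylamino stands in place of ureido, four bonds along the chain from an amine nitrogen.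

Going by the values given here, only one measured step bears on this change. It is modest: a 3.5-fold higher number from compound 1 to compound 2 (0.54 log units; beyond the scatter), with 3-ureidopropyl in place of 3-aminoprop-1-en-1-yl. Like compound 1, compound 3 ends its chain in an amine rather than a ureido group, although the two chains and amines differ. A modest fall towards the value of compound 1, 2 nm/s, is therefore expected. The expected change is a 2.3-fold lower number from compound 2 to compound 3 (0.37 log units; beyond the scatter). For compound 3 the estimated value is 3 nm/s, with an expected range from 1 nm/s to 9 nm/s.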

Compound 3, apparent permeability: 3 nm/s
For compound 3 middle estimate and measured number coincide at the digits printed; the range from low to high includes it.
By their numbers in this assay, from the lowest: compounds 1 and 3 (each within the scatter of the next); then compound 2.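

In this assay, the ureido end of the chain is now exchanged directly for an amine at the same place, four bonds along the chain from an amine nitrogen, and diethylamino in place of ureido gives a 2.3-fold lower number from compound 2 to compound 3 (0.37 log units; beyond the scatter). Compound 3 differs from compound 1 in both its chain and its amine, yet the step between them is a 1.5-fold higher number from compound 1 to compound 3 (0.18 log units; within the scatter), so these differences together leave the two numbers within the scatter of each other. The data given offer no explanation for either step.

On these data alone, with ureido carried by compound 2 alone, it stays open whether the higher number belongs to that group or to this one compound. As far as these compounds go, how a carboxylic acid or a simple amide at the end of this chain, or a longer chain, would read in this assay also stays open.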